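Swapping pyridin-3-yl for benzyl on a shared core

A few compounds are considered here, and "the series" means these few. Any claim that something is new, unique, unknown or untested is made for them only; others in the source may bear on it.

In a functional assay on MCF7 cells (Homo sapiens) for cytotoxicity, read by WST assay, with a stated time of 72 h (on this read-out higher numbers stand for weaker inhibition and lower numbers for stronger inhibition), compound 1 `O=C1Nc2c(ccc(F)c2F)C1(c1ccccc1)c1ccc(O)cc1` gives 7.1 nM, compound 2 `COc1ccc(C2(c3cccc(O)c3)C(=O)Nc3c2ccc(F)c3F)cc1` gives 196 nM, and compound 3 `O=C1Nc2c(ccc(F)c2F)C1(c1ccc(O)cc1)c1cccnc1` gives 63 nM, the middle number of the three. Compound 4 `O=C1Nc2c(ccc(F)c2F)C1(Cc1ccccc1)c1ccc(O)cc1` has not yet been measured. It carries benzyl in place of pyridin-3-yl on a saturated ring carbon. Going by the values given here, only one measured step changes this same group: an 8.9-fold higher number from compound 1 to compound 3 (0.95 log units; beyond the scatter), with pyridin-3-yl in place of phenyl, and it is beyond the scatter. Benzyl has an all-carbon ring like the phenyl of compound 1, but no measured compound carries benzyl, so the guidance is weak. In this assay no change beyond the scatter is expected, and the estimated step is a 1.3-fold lower number from compound 3 to compound 4 (0.10 log units; within the scatter). For compound 4 the estimate is 50 nM, with an expected range of 8 nM to 300 nM.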

Compound 4, half-maximal inhibitory concentration: > 1000 nM
Compound 4 gave a limit, no number; the forecaster's own chance of this, stated with the estimate: 5%; middle value at least 20-fold (1.30 log units) from the limit.
By their numbers in this assay, from the lowest: compound 1; then compound 3; then compound 2. At a limit, above all of these: compound 4.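

In this assay, putting benzyl on this saturated ring carbon gives an at least 15-fold higher number from compound 3 to compound 4 (1.20 log units; beyond the scatter), and an at least 140-fold higher number from compound 1 to compound 4 (2.14 log units; beyond the scatter). An all-carbon ring is therefore not enough to keep the low number of compound 1, and what joins that ring to the shared core matters here. The result for compound 4 is a limit, not a number: the limit of > 1000 nM in this assay, at which 1 of the 4 values shown sits.

Going by these compounds, it remains open how phenethyl, with its longer chain, or a small group such as methyl would read at this carbon. On these data alone, the true value of compound 4 also remains open.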